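A few compounds are considered here, and "the series" means these few. Any claim that something is new, unique, unknown or untested is made for them only; others in the source may bear on it.

Measured so far:
- compound 1, `CCn1c(=O)[nH]c2ccc(OCCOc3ccc(OC)cc3)cc21`: 13.9%
- compound 2, `Cn1c(=O)[nH]c2ccc(OCCOc3ccc(Cl)cc3)cc21`: 9.94%
- compound 3, `CCn1c(=O)[nH]c2ccc(OCCOc3ccc(Cl)cc3)cc21`: 7.24%

All three share one core and were tested in an assay on cells for inhibition of Amine oxidase [flavin-containing] B (Homo sapiens), read by fluorescence, with stated times of 30 min and 15 min, tested at 1 uM; a higher number here means more inhibition at the concentration tested (going by the name of the read-out), a lower number less inhibition. Compound 3 gives the lowest of the three numbers, but its neighbours sit close: a number 2.7 percentage points lower from compound 2 to compound 3 (within the scatter) and a number 6.7 percentage points lower from compound 1 to compound 3 (within the scatter), both within the scatter, so the three compounds cannot be told apart on these figures.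

Compound 4, `CCn1c(=O)[nH]c2ccc(OCCOc3cccc(F)c3)cc21`, is the next step. It differs from compound 3 in one place: 3-fluorophenyl in place of 4-chlorophenyl on an oxygen on a saturated carbon.

Going by the values given here, only one measured step touches the same part of the molecule, the ring at the far end of the chain: a number 6.7 percentage points lower from compound 1 to compound 3 (within the scatter), which was within the scatter. The other step, a number 2.7 percentage points lower from compound 2 to compound 3 (within the scatter), concerns the group on the core nitrogen and says nothing about this ring. With a single small step as guide, no movement beyond the scatter is expected for compound 4 in this assay, and the estimated step is a number 1.8 percentage points higher from compound 3 to compound 4 (within the scatter).

Compound 4 is therefore expected to give about 9% in this assay, estimated to fall between 1% and 19%.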

Compound 4, a percentage reported as inhibition, at one concentration (the size of the read-out at that concentration, not a potency): 30.3%
Beside the measured number, compound 4's estimate is 21.3 percentage points below it, outside the stated range (above it).
By their numbers in this assay, from the lowest: compounds 3, 2 and 1 (each within the scatter of the next); then compound 4.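

In this assay, replacing the ring at the far end of the chain gives a number 23.1 percentage points higher from compound 3 to compound 4 (beyond the scatter), and the comparison with the methoxy-bearing ring gives a number 16.4 percentage points higher from compound 1 to compound 4 (beyond the scatter). Going by these compounds alone, the earlier swap of 4-methoxyphenyl for 4-chlorophenyl stayed within the scatter, so these are the first steps to show that the group on this oxygen on a saturated carbon can move the read-out by more than ordinary scatter, though the size remains modest and comes from a single tested concentration. Nothing available here explains why 3-fluorophenyl stands apart from the other two rings.

This change replaces chlorine with fluorine and also moves the substituent, as the names 4-chlorophenyl and 3-fluorophenyl show, so these compounds cannot say whether the halogen, its place on the ring, or both account for the step. Also open, on these data alone, are how a plain phenyl ring or a ring carrying a nitrile would compare, and whether the 3-fluorophenyl step would hold with a methyl rather than an ethyl group on the nitrogen of the shared core.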